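Swapping an Aromatic Ring for a Plain Chain

A few compounds are considered here, and "the series" means these few. Any claim that something is new, unique, unknown or untested is made for them only; others in the source may bear on it.

Of the compounds shown here, three that share one core have been tested in a functional assay on cells (Lymphocyte, Homo sapiens); on this read-out lower numbers stand for stronger inhibition and higher numbers for weaker inhibition. Compound 1 `Nc1nc(N2CCN(C(=O)OCc3ccccc3)CC2)c2nc(-c3ccc(F)cc3)sc2n1` gives 4900 nM. Among the measured compounds shown here, compound 3 `Nc1nc(N2CCN(C(=O)COc3ccccc3)CC2)c2nc(-c3ccc(F)cc3)sc2n1` gives 90 nM, and the only single change measured so far, a 54-fold lower number from compound 1 to compound 3 (1.74 log units; beyond the scatter), concerns the group on the carbonyl carbon. Compound 2 `Nc1nc(N2CCN(C(=O)COc3ccc(Cl)cc3)CC2)c2nc(CCc3ccc(F)cc3)sc2n1` gives 4400 nM; that number stands second highest of the three, close to compound 1 and far from compound 3.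

Compound 4 `CCCCCc1nc2c(N3CCN(C(=O)COc4ccc(Cl)cc4)CC3)nc(N)nc2s1` has not yet been measured. It differs from compound 2 in one place: propyl in place of 4-fluorophenyl on a saturated chain carbon, two bonds along the chain from an aromatic carbon. For the measured compounds named here, the one measured step concerns the group on the carbonyl carbon, not this chain, so it does not speak to the present change. Going by the values given here, compound 1 and compound 3 carry 4-fluorophenyl directly on the core, so no measured pair shows what putting propyl in place of 4-fluorophenyl does. With nothing bearing on the change, the expectation for compound 4 is a number near that of compound 2, within the usual scatter, though the range must stay wide. Compound 4 is therefore estimated at 4400 nM, between 1200 nM and 16000 nM, which corresponds to an expected step of no change at the digits printed from compound 2 to compound 4 (within the scatter).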

Compound 4, half-maximal inhibitory concentration: 690 nM
Compound 4: the middle estimate sits 6.4-fold (0.80 log units) above what was measured; measured number outside the range, below it.
By their numbers in this assay, from the lowest: compound 3; then compound 4; then compounds 2 and 1 (each within the scatter of the next).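

In this assay, trading the ring-bearing 2-(4-fluorophenyl)ethyl group of compound 2 for the plain pentyl chain of compound 4 gives a 6.4-fold lower number from compound 2 to compound 4 (0.80 log units; beyond the scatter), so with this phenoxyacetyl-type side on the piperazine-bearing part of the molecule, the 4-fluorophenyl ring is not required for inhibition, and inhibition is stronger without it. Among the compounds shown here, this is the first measured step at this position, since the earlier step concerned only the group on the carbonyl carbon, and it shows that the read-out responds to what sits at the end of this chain as well. Nothing given here explains why the plain chain does better than the aromatic ring.

This single pair cannot show whether the gain depends on the length of the chain, which a shorter ethyl group or a longer heptyl group would help to test, or whether a pentyl chain ending in an amine or a carboxylic acid would keep it. It also leaves open whether the same swap would give a similar step with a different group on the carbonyl carbon, such as the benzyloxy group of compound 1.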